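Shortening the alkyne chain: from compound 2 to compound 4

The source may report more compounds than this note shows. Statements on the series, on what has been measured and on what is new or still open speak of the compounds shown alone.

In a functional assay on HEL cells (Homo sapiens) (a lower number here means that less compound is tolerated, a higher number that more compound is tolerated), compound 1 `CCCCCCCCCc1cc2cn(COCCO)c(=O)nc2o1` gives only a limit: >= 100000 nM.
In this assay compound 2 `CCCCCC#Cc1cc2cn(COCCO)c(=O)nc2o1` gives only a limit: > 50000 nM.
In this assay compound 3 `CCCCCCc1cc2cn(COCCO)c(O)nc-2n1` gives only a limit: > 200000 nM.

None of the three measured compounds gives a number in this assay; each sits at a limit of the assay. Compound 2 stands at the limit of > 50000 nM in this assay, at which 1 of the 3 values shown sits. Within the data shown here, the other two compounds also sit at limits, one at the limit of >= 100000 nM in this assay, at which 1 of the 3 values shown sits, and one at the limit of > 200000 nM in this assay, at which 1 of the 3 values shown sits, so no ordering among the three can be read from these values, and no step between two measured compounds can be sized.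

Compound 4 `CCCCC#Cc1cc2cn(COCCO)c(=O)nc2o1` has not yet been measured in this assay. It differs from compound 2 in one place: hydrogen in place of methyl on a saturated chain carbon, four bonds along the chain from a triple-bonded carbon. The change is small, the loss of a single carbon from the saturated chain, four bonds along the chain from a triple-bonded carbon.

With every measured compound at a limit, the step from compound 2 to compound 4 is expected to be none beyond the scatter, and compound 4 is expected to remain at a limit as well; the expected step is a step that the limit leaves unreadable from compound 2 to compound 4. Compound 4 is estimated at 60000 nM, within the range 20000 nM to 300000 nM.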

Compound 4, half-maximal cytotoxic concentration: > 50000 nM
Compound 4 was reported as a limit; the forecaster's own chance of this, stated with the estimate: 85%; the middle value does not contradict the limit.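

In this assay compound 2 and compound 4 both stand at the same limit, so no step between them can be read: the limit of > 50000 nM in this assay, at which 2 of the 4 values shown sit.

The compounds shown leave open at what concentration any of them becomes cytotoxic, and whether the loss of a single carbon from the saturated chain changes that concentration at all.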